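The source may hold more compounds than are shown below. What is called first, only, known or untested is meant among the compounds shown, and "the series" means these compounds.

Three compounds share a common core, a five-membered aromatic ring bearing a carboxymethyl group, and differ only in the aromatic groups attached to it. Compound 1 `O=C(O)Cc1sc(C(c2ccccc2)c2ccc(F)cc2)nc1-c1ccc(Cl)cc1` gives 17 nM in an in vitro assay on HEK385-7 cells for displacement of a labelled ligand from prostaglandin D2 receptor 2 (Homo sapiens) (on this read-out higher numbers stand for weaker inhibition and lower numbers for stronger inhibition), compound 2 `O=C(O)Cc1sc(C(c2ccccc2)c2ccccc2)nc1-c1ccc(F)cc1` gives 8.7 nM, and compound 3 `O=C(O)Cc1sc(C(c2ccc(F)cc2)c2ccc(F)cc2)nc1-c1cc(F)cc(F)c1` gives 35 nM, the highest of the three numbers, with compound 1 nearest to it and compound 2 furthest away. Compound 4 `Cc1cc(-c2nc(C(c3ccc(F)cc3)c3ccc(F)cc3)sc2CC(=O)O)ccn1` has not yet been measured. It differs from compound 3 in one place: 2-methylpyridin-4-yl in place of 3,5-difluorophenyl on an aromatic carbon. Within the data shown here, no measured pair shows the effect of such an exchange, so the step from compound 3 to compound 4 is expected to stay within the scatter, with no clear direction, and compound 4 is estimated at 30 nM (range 10 nM to 90 nM), an expected step of a 1.2-fold lower number from compound 3 to compound 4 (0.07 log units; within the scatter).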

Compound 4, half-maximal inhibitory concentration: 3.1 nM
Compound 4: middle estimate off by 9.7-fold (0.99 log units), on the high side; measured number below the stated range.
By their numbers in this assay, from the lowest: compound 4; then compounds 2 and 1 (each within the scatter of the next); then compound 3.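

Swapping 3,5-difluorophenyl for 2-methylpyridin-4-yl on this aromatic carbon, next to the ring nitrogen, gives an 11-fold lower number from compound 3 to compound 4 (1.05 log units; beyond the scatter) in this assay and shows that the position responds strongly to the group it carries. A ring containing nitrogen and bearing a methyl group is well accepted here, and it adds a hydrogen-bond acceptor that the departing group lacks. Nothing available explains the gain. The compounds shown do not separate the ring nitrogen from the methyl group: plain pyridin-4-yl and 3-methylphenyl would be the telling comparisons.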